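The source may hold more compounds than are shown below. What is called first, only, known or untested is meant among the compounds shown, and "the series" means these compounds.

Working notes on the series. Going by the values given here, in a functional assay on KB cells (Homo sapiens) for inhibition, read by sulforhodamine B assay (a lower number here means a stronger inhibitor of growth, a higher number a weaker inhibitor of growth), compound 1 (`COc1ccc(-c2ccc(-c3ccc(-c4nc5cc(C)ccc5[nH]4)cc3)cc2)cc1OC`) gives 2190 nM, the lower of the two numbers so far, and compound 2 (`COc1ccc(-c2ccc(-c3ccc(-c4nc5ccccc5[nH]4)cc3)cc2)cc1OC`) gives 9250 nM. Among the compounds with values here, the only measured step, a 4.2-fold higher number from compound 1 to compound 2 (0.63 log units; beyond the scatter), is hydrogen in place of methyl on an aromatic carbon, with the 3,4-dimethoxyphenyl group the same on both sides. Compound 3 (`Cc1ccc2[nH]c(-c3ccc(-c4ccc(-c5ccc(OC(F)(F)F)cc5)cc4)cc3)nc2c1`) keeps that methyl and differs from compound 1 elsewhere: 4-(trifluoromethoxy)phenyl in place of 3,4-dimethoxyphenyl on an aromatic carbon. Here 4-(trifluoromethoxy)phenyl stands in place of 3,4-dimethoxyphenyl on an aromatic carbon. Within the data shown here, no measured compound carries the entering group, and no measured step alters the leaving one. Among the measured compounds shown here, the single step of a 4.2-fold higher number from compound 1 to compound 2 (0.63 log units; beyond the scatter) therefore bears only indirectly, as a rough measure of how far one change has moved the number, and it gives no direction for this replacement. With so little to go on, no clear shift is expected, and the estimated change is a 1.3-fold higher number from compound 1 to compound 3 (0.11 log units; within the scatter), with the direction uncertain. In this assay the estimate for compound 3 is 2800 nM, expected to lie between 700 nM and 10000 nM.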

Compound 3, concentration for 50% growth inhibition: 41200 nM
For compound 3 the middle estimate is 15-fold (1.17 log units) below the measured one; the whole stated range lies below it.
By their numbers in this assay, from the lowest: compound 1; then compound 2; then compound 3.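

In this assay, going by these compounds alone, the group on the aromatic carbon para to a large group proves far from neutral: with the methyl kept, the replacement gives a 19-fold higher number from compound 1 to compound 3 (1.27 log units; beyond the scatter), a large step, whereas the only earlier step, at the methyl, was modest at a 4.2-fold higher number from compound 1 to compound 2 (0.63 log units; beyond the scatter). This gives the first direction for this place, as 4-(trifluoromethoxy)phenyl makes a much weaker inhibitor of growth than 3,4-dimethoxyphenyl, and in the compounds at hand this change moves the number further than removing the methyl does. No independent measurement is available to explain the size or direction of this step.

Within the data shown here, the single replacement changes the substituents on the ring as a whole, so it remains open whether the loss follows from the departure of the two methoxy groups or from the arrival of the trifluoromethoxy group. Going by these compounds, a plain phenyl ring, a single methoxy group or an amine on that ring would help separate the two readings, and the effect of removing the methyl from compound 3 also remains open.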